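The compounds below may be only part of what the source reports. "The series", "measured", "known", "first", "only" and "open" are said of these compounds alone.

Measured in an ADME assay (liver) for metabolic stability, with Liver microsome (Homo sapiens) as the target, read by LC-MS, using microsomes and NADPH, with a stated time of 5 min, at 37 degrees C; on this read-out lower numbers stand for slow clearance and higher numbers for fast clearance:
Compound 1 `CCn1c([C@@H](C)NS(=O)(=O)C2CC2)nc2ccc(C(F)(F)F)cc21`: < 3 mL.min-1.g-1 (a limit)
Compound 2 `CCn1c([C@@H](C)NS(=O)(=O)c2ccccc2)nc2ccc(C(F)(F)F)cc21`: 14 mL.min-1.g-1
Compound 3 `CCn1c([C@@H](C)NS(=O)(=O)c2cccc(Cl)c2)nc2ccc(C(F)(F)F)cc21`: > 100 mL.min-1.g-1 (a limit)

Of these three, compound 3 stands at the fast-clearance end. Compound 3 gives > 100 mL.min-1.g-1, which is a limit and not a number.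

The next compound is compound 4 `CCn1c([C@@H](C)NS(=O)(=O)c2cccc(C#N)c2)nc2ccc(C(F)(F)F)cc21`, which has cyano in place of chloro on an aromatic carbon. The step that bears most closely is an at least 7.1-fold higher number from compound 2 to compound 3 (0.85 log units; beyond the scatter), at least modest and beyond the scatter, which brought in the chloro that now leaves. The wider step an at least 33-fold higher number from compound 1 to compound 3 (1.52 log units; beyond the scatter) is large, while an at least 4.6-fold higher number from compound 1 to compound 2 (0.66 log units; beyond the scatter) is at least modest. For the measured compounds named here, no measured compound carries cyano, so its own contribution is unknown. In this assay, a move toward lower numbers is therefore expected, giving back much of the chloro step, though probably not all of it. The expected change is an at least 3.3-fold lower number from compound 3 to compound 4 (0.52 log units; beyond the scatter). For compound 4 the estimated value is 30 mL.min-1.g-1, within an expected range of 10 mL.min-1.g-1 to 90 mL.min-1.g-1.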

Compound 4, intrinsic clearance in microsomes: > 100 mL.min-1.g-1
Compound 4 was reported as a limit; the forecaster's own chance of this, stated with the estimate: 15%; middle value at least 3.3-fold (0.52 log units) from the limit.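

For the compounds shown here, with cyano in place of hydrogen on the aromatic carbon meta to a large group, this assay gives an at least 7.1-fold higher number from compound 2 to compound 4 (0.85 log units; beyond the scatter), so chloro is not the only group at this place that goes with a higher number than that of the unsubstituted phenyl. The 3-cyanophenyl group in place of cyclopropyl on the sulfonyl sulfur likewise gives an at least 33-fold higher number from compound 1 to compound 4 (1.52 log units; beyond the scatter). Compound 3 and compound 4 share one limit, so the step between them cannot be read and neither can be ranked over the other: the limit of > 100 mL.min-1.g-1 in this assay, at which 2 of the 4 values shown sit.

From the compounds shown here alone, how far compound 3 and compound 4 lie past that limit, and whether chloro and cyano differ at all, stays open. Also open, going by these compounds, is whether a methoxy group or a carboxylic acid at this same place would bring the number back toward that of compound 2.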